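The source may report more compounds than this note shows. Statements on the series, on what has been measured and on what is new or still open speak of the compounds shown alone.

Measured in a functional assay on T47D cells (Homo sapiens) for cytotoxicity, read by CCK-8 assay and cell counting, with a stated time of 2 days; on this read-out higher numbers stand for weaker inhibition and lower numbers for stronger inhibition:
compound 1 `Oc1ccc(-c2cc(-c3ccc(Cl)cc3)nc(-c3cccnc3)c2)cc1` gives 29300 nM
compound 2 `Oc1ccc(-c2cc(-c3ccco3)nc(-c3ccccc3Cl)c2)cc1` gives 5480 nM
compound 3 `Oc1ccc(-c2cc(-c3ccccc3)nc(-c3ccc(Cl)cc3)c2)cc1` gives 4270 nM

Compound 3 holds the lowest number of the three, though its gap to compound 2 lies within the scatter; only compound 1 stands clearly apart from it. Compound 4 `Oc1ccc(-c2cc(-c3ccc(Cl)cc3)nc(-c3ccco3)c2)cc1` follows from compound 3 by one change: furan-2-yl in place of phenyl on an aromatic carbon. Going by the values given here, no measured step covers this particular exchange. Among the compounds with values here, the single step that touches the same place is the change from pyridin-3-yl to phenyl, a 6.9-fold lower number from compound 1 to compound 3 (0.84 log units; beyond the scatter), which shows that a different aromatic group at this carbon can shift the number by a modest amount. Compound 2 also carries furan-2-yl, but together with 2-chlorophenyl rather than 4-chlorophenyl, so its value and that of compound 3 can only be set side by side, not treated as a step; the two lie within the scatter of each other. On this basis the exchange in compound 4 is expected to move the number little, and the step is estimated as a 1.2-fold higher number from compound 3 to compound 4 (0.07 log units; within the scatter). Compound 4 is therefore expected to give about 5000 nM in this assay, within a range from 2000 nM to 13000 nM.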

Compound 4, half-maximal inhibitory concentration: 6260 nM
The estimate for compound 4 lay 1.3-fold (0.10 log units) below the measured number, and the stated range covers the measured number.
By their numbers in this assay, from the lowest: compounds 3, 2 and 4 (each within the scatter of the next); then compound 1.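

In this assay, the exchange at the aromatic carbon next to the ring nitrogen now has a direct measure, and furan-2-yl in place of phenyl gives a 1.5-fold higher number from compound 3 to compound 4 (0.17 log units; within the scatter) with the 4-chlorophenyl group kept in place. With furan-2-yl on that carbon, the second aryl group can also be compared, and 4-chlorophenyl in place of 2-chlorophenyl gives a 1.1-fold higher number from compound 2 to compound 4 (0.06 log units; within the scatter), so these two chlorophenyl groups are not told apart here. Pyridin-3-yl is now set apart from two other aromatic groups at the same carbon, by a 6.9-fold lower number from compound 1 to compound 3 (0.84 log units; beyond the scatter) for phenyl and by a 4.7-fold lower number from compound 1 to compound 4 (0.67 log units; beyond the scatter) for furan-2-yl, while phenyl and furan-2-yl lie within the scatter of each other.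

The compounds shown leave open how a non-aromatic group at this carbon, such as an amine or a morpholine ring, would compare, and whether the hydroxyl of the 4-hydroxyphenyl group could give way to a methoxy group. Nothing given here accounts for the distance of compound 1 from the other three.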